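A few compounds are considered here, and "the series" means these few. Any claim that something is new, unique, unknown or untested is made for them only; others in the source may bear on it.

Of the compounds shown here, two have been measured so far. Compound 1 `COC(=O)C#CC(O/C=C/C(=O)OC)C(C)c1ccccc1` gives 490 nM in a functional assay on HBL-100 cells (Homo sapiens) for antiproliferative activity, read by sulforhodamine B assay, with a stated time of 48 h; a higher number here means a weaker inhibitor of growth, a lower number a stronger inhibitor of growth. Compound 2 `CCCC(C#CC(=O)OC)O/C=C/C(=O)OC` gives 270 nM in this assay, the lowest of the two numbers, though its gap to compound 1 lies within the scatter of repeated measurements, so no order between the two can be read from these values. Compound 3 `COC(=O)C#CC(O/C=C/C(=O)OC)C1CC1` has not yet been measured. It differs from compound 2 in a single place: cyclopropyl in place of propyl on a saturated chain carbon bound to an oxygen on an unsaturated carbon and a triple-bonded carbon. Among the measured compounds shown here, no step between measured compounds bears on this exchange, so nothing in the data points to a direction. The author therefore expects a step of a 1.1-fold higher number from compound 2 to compound 3 (0.05 log units; within the scatter) that stays within the scatter, with no clear movement either way. Compound 3 is estimated to give 300 nM in this assay, with a likely range from 120 nM to 800 nM.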

Compound 3, concentration for 50% growth inhibition: 250 nM
Estimate against measurement, compound 3: 1.2-fold (0.08 log units) above; the measured number falls inside the stated range.
By their numbers in this assay, from the lowest: compounds 3, 2 and 1 (each within the scatter of the next).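

In this assay, among the compounds shown here, cyclopropyl in place of propyl gives a 1.1-fold lower number from compound 2 to compound 3 (0.03 log units; within the scatter), the first step that can be read at a single place. On this saturated chain carbon, bound to an oxygen on an unsaturated carbon and a triple-bonded carbon, a three-membered ring of carbon and an open chain of the same three carbons therefore cannot be told apart in this assay. Nothing on hand speaks to the reason for this result.

As far as these compounds go, whether a longer chain, an amine or a carboxylic acid on this carbon would shift the number beyond the scatter remains open. So does whether the exchange of propyl for cyclopropyl would read the same way on another core or in another cell line.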